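A few compounds are considered here, and "the series" means these few. Any claim that something is new, unique, unknown or untested is made for them only; others in the source may bear on it.

Notes on the series. In a functional assay on MCF7 cells (Homo sapiens) for inhibition, read by fluorescence, with a stated time of 72 h (a lower number here means a stronger inhibitor of growth, a higher number a weaker inhibitor of growth), compound 1 `Cc1nc(CCO)cc2nn(-c3ccccc3)cc12` gives > 100000 nM, a limit of the assay rather than a number. Compound 2 `OCCc1cc2nn(-c3ccccc3)cc2cn1` gives > 100000 nM, again a limit and not a number. Compound 3 `CCCCc1cc2nn(-c3ccccc3)cc2c(C)n1` gives 11100 nM. The step from compound 1 to compound 2 is a step that the two limits leave unreadable from compound 1 to compound 2, so nothing can be read from it. For the measured compounds named here, the step of an at least 9.0-fold lower number from compound 1 to compound 3 (0.95 log units; beyond the scatter) is the one readable change, and its reading rests on (the limit of > 100000 nM in this assay, at which 2 of the 3 values shown sit). Compound 2 therefore stands at the limit of the assay. Only compound 3 gives a number.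

Compound 4 `c1ccc(-n2cc3cnc(C4CC4)cc3n2)cc1` differs from compound 2 by cyclopropyl in place of 2-hydroxyethyl on an aromatic carbon. The measured change that bears on it is the loss of the hydroxy group, which in the step of an at least 9.0-fold lower number from compound 1 to compound 3 (0.95 log units; beyond the scatter) went with a fall in the number; that step, however, was measured on the core of compound 1, which carries a methyl group that compound 2 and compound 4 lack. A fall of roughly that order is expected here, an at least 3.3-fold lower number from compound 2 to compound 4 (0.52 log units; beyond the scatter), though the limit on compound 2 leaves the true size of the expected step open. Compound 4 is expected to give 30000 nM, between 8000 nM and 100000 nM.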

Compound 4, concentration for 50% growth inhibition: 69300 nM
Compound 4: the middle estimate sits 2.3-fold (0.36 log units) below what was measured; the range from low to high includes it.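

In this assay, the change from 2-hydroxyethyl to cyclopropyl on the aromatic carbon next to the ring nitrogen reads as an at least 1.4-fold lower number from compound 2 to compound 4 (0.15 log units; that floor lies within the scatter), so the printed floor alone does not establish a change beyond the scatter. For the compounds shown here, compound 2 gives > 100000 nM, which is a limit and not a number, and the true size of this step therefore stays open: the limit of > 100000 nM in this assay, at which 2 of the 4 values shown sit. What compound 4 adds is the first measured number on the core without the methyl group, whereas the earlier readable step rested on the core of compound 1.

The enter and leave groups differ at once in the hydroxy group and in the three-membered ring, so this one step cannot separate the two, and a plain ethyl or a longer chain ending in a methoxy group at this position would be needed to tell them apart. Also open, going by these compounds, is how an amine or a carboxylic acid at this position would read, and whether the methyl group of the core of compound 1 alters the size of the step, since compound 3 and compound 4 differ in more than one place and cannot be compared directly.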